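Swapping One Halogenated Phenyl Ring for Another

This account rests on a few compounds, and the source may have more. Where it says the series, first, only, none or still open, it means among the compounds named here.

Compound 1, `CCOC(=O)c1c(-c2cccc(F)c2)[nH]c2cc(OC)ccc2c1=O`, gives > 100000 nM in a physicochemical assay for solubility, in phosphate buffer, at pH 7.4 (on this read-out higher numbers stand for higher solubility and lower numbers for lower solubility), a limit of the assay rather than a number.
Compound 2, `CCOC(=O)c1c(-c2cccc(C(F)(F)F)c2)[nH]c2cccc(OC)c2c1=O`, gives > 100000 nM in this assay, again a limit.

For the measured compounds named here, compound 1 thus has no exact solubility number; it stands at the limit of > 100000 nM in this assay, at which 2 of the 2 values shown sit, and the one other value shown is a limit as well. Compound 3, `CCOC(=O)c1c(-c2ccc(Cl)cc2)[nH]c2cc(OC)ccc2c1=O`, has not yet been measured. It differs from compound 1 by 4-chlorophenyl in place of 3-fluorophenyl on an aromatic carbon. Going by the values given here, no step between two measured compounds is available here, so the effect of this change cannot be read from a measured pair, and two values at the limit give no direction. The change is expected to make no difference beyond the usual scatter, with an estimated step of a number no higher from compound 1 to compound 3 (the limit leaves the size open). Compound 3 is expected to give about 100000 nM, within a range from 30000 nM to 300000 nM, and may again be reported only as a limit.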

Compound 3, solubility: 3000 nM
For compound 3 the middle estimate is 33-fold (1.52 log units) above the measured one; measured number outside the range, below it.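

The aryl group on this aromatic carbon, next to the ring nitrogen, turns out to matter in this series: 4-chlorophenyl in place of 3-fluorophenyl gives an at least 33-fold lower number from compound 1 to compound 3 (1.52 log units; beyond the scatter) in this assay. For the compounds shown here, compound 3, at 3000 nM, is also the first compound here with an exact number rather than a limit, so this change on the shared core can bring the read-out into the measurable range. Compound 1 carries only a limit, so the step gives a minimum and not a true size: the limit of > 100000 nM in this assay, at which 2 of the 3 values shown sit.

This change alters both the halogen and where it sits on the phenyl ring, and the compounds shown cannot separate the two or say why the number falls. Also open, on these data alone, is how a phenyl ring carrying an amine or a carboxylic acid at this carbon would read in this assay.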